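Chain homologation of the amide acid in the oxazepine series

The compounds below may be only part of what the source reports. "The series", "measured", "known", "first", "only" and "open" are said of these compounds alone.

Compound 2 `COc1cccc([C@H]2O[C@H](CC(=O)N[C@@H](C)C(=O)O)C(=O)N(CC(C)(C)CO)c3ccc(Cl)cc32)c1OC` gives 14% in a functional assay on the whole organism for inhibition, with Rattus norvegicus as the target, at a dose of 10 mg/kg by the oral route (on this read-out higher numbers stand for more inhibition at the one dose given (going by the name of the read-out) and lower numbers for less inhibition), level with compound 1 `COc1cccc([C@H]2O[C@H](CC(=O)NCC(=O)O)C(=O)N(CC(C)(C)CO)c3ccc(Cl)cc32)c1OC`, which gives 14% in this assay; the step of no change at the digits printed from compound 1 to compound 2 (within the scatter) lies within the scatter. Compound 3 `COc1cccc([C@H]2O[C@H](CC(=O)N3CCC(CC(=O)O)CC3)C(=O)N(CC(C)(C)CO)c3ccc(Cl)cc32)c1OC` gives 77%; 64% (2 entries) in this assay, with the repeated entries shown in the several entries of compound 3 in this assay, 77%; 64% (2 entries). Among the compounds with values here, no measured step joins compound 3 to compound 1 or compound 2, so its values are recorded without comparison.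

Compound 4 `COc1cccc([C@H]2O[C@H](CC(=O)NCCC(=O)O)C(=O)N(CC(C)(C)CO)c3ccc(Cl)cc32)c1OC` differs from compound 2 by 2-carboxyethyl in place of 1-carboxyethyl on an amide-type nitrogen. Within the data shown here, the only measured step, from compound 1 to compound 2, concerns a methyl on the chain carbon and showed nothing beyond the scatter; no measured step covers moving the carboxyl one carbon further out. The working expectation is therefore a step of a number 8 percentage points higher from compound 2 to compound 4 (within the scatter) that stays within the scatter, with a wide margin on the upper side given the read-out of compound 3.

Compound 4 is expected to give 22% in this assay, estimated between 2% and 50%.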

Compound 4, a percentage reported as inhibition, in the whole organism at one dose (the size of the read-out at that dose, not a potency): 19%
The estimate for compound 4 lay 3 percentage points above the measured number, and the stated range covers the measured number.
By their numbers in this assay, from the lowest: compounds 1, 2 and 4 (each within the scatter of the next).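

In this assay the shift of the carboxyl along the chain on the amide-type nitrogen gives a number 5 percentage points higher from compound 2 to compound 4 (within the scatter) and so 2-carboxyethyl and 1-carboxyethyl cannot be told apart here. Carboxymethyl in place of carboxy on the saturated chain carbon, which lengthens the chain, gives a number 5 percentage points higher from compound 1 to compound 4 (within the scatter) and so the longer chain cannot be told apart from the shorter one either. Together with the methyl step, this shows that both branching and lengthening of the acid chain at this position stay within the scatter across compound 1, compound 2 and compound 4.

Going by these compounds, whether a still longer chain such as 3-carboxypropyl on the amide-type nitrogen would stay level remains open. No single step links these compounds to compound 3, so what sets its number apart also remains open, its values reading: the several entries of compound 3 in this assay, 77%; 64% (2 entries)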